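Methyl on an Amide Nitrogen: A Small Step Expected

The source may report more compounds than this note shows. Statements on the series, on what has been measured and on what is new or still open speak of the compounds shown alone.

Of the compounds shown here, two with a shared core have been measured. Compound 1 `COc1ccc(-c2cc(NC(=O)CCC(=O)N(C)CC(=O)NCc3ccccc3)nc(-c3ccc(OC)cc3)n2)cc1` gives 35400 nM in an assay on HeLa cells for displacement of a labelled ligand from adenosine receptor A3 (Homo sapiens), read by fluorescence polarization, with a stated time of 30 min; a higher number here means a weaker inhibitor, a lower number a stronger inhibitor. Compound 2 `COc1ccc(-c2cc(NC(=O)COCC(=O)NCC(=O)NC3CCCCC3)nc(-c3ccc(OC)cc3)n2)cc1` gives 21400 nM in this assay. Compound 2 has the lowest of these two numbers, but its nearest neighbour, compound 1, sits within the usual scatter of repeated measurements, so the two cannot be told apart on these data.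

Compound 3 `COc1ccc(-c2cc(NC(=O)COCC(=O)N(C)CC(=O)NC3CCCCC3)nc(-c3ccc(OC)cc3)n2)cc1` is built from compound 2 by one change: methyl in place of hydrogen on an amide-type nitrogen, in words a methyl in place of hydrogen on an amide-type nitrogen. Among the compounds with values here, no measured pair differs by this change alone, so there is no measured step to lean on. Compound 1 also carries a methyl on an amide-type nitrogen, but it differs from compound 2 elsewhere as well, so it only shows that such a methyl is compatible with a weak number.

Compound 3 is therefore expected at 21000 nM, with a range from 8000 nM to 55000 nM. The step of a 1.0-fold lower number from compound 2 to compound 3 (0.01 log units; within the scatter) is expected to stay within the scatter, in no firm direction.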

Compound 3, inhibition constant: 23700 nM
Estimate against measurement, compound 3: 1.1-fold (0.05 log units) below; the measured number falls inside the stated range.
By their numbers in this assay, from the lowest: compounds 2, 3 and 1 (each within the scatter of the next).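

In this assay, within the data shown here, this pair isolates the change for the first time and gives a 1.1-fold higher number from compound 2 to compound 3 (0.04 log units; within the scatter), so compound 2 and compound 3 cannot be told apart. At this amide-type nitrogen, whose other neighbours are a carbonyl carbon and a saturated chain carbon, a methyl can therefore take the place of the hydrogen without a step beyond the scatter. Compound 1 could not show this, as it carries such a methyl but also differs from compound 2 elsewhere, and no measurement shown here offers a reason for the result.

As far as these compounds go, what remains open is whether this tolerance extends beyond a single methyl, for example to an ethyl group, a longer chain, or a chain ending in an amine or a carboxylic acid at the same nitrogen. It is also unknown whether a methyl on the nitrogen of the cyclohexylcarbamoyl group would give a similar result, or whether replacing the cyclohexyl group itself would produce a step beyond the scatter.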